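Replacing the anilino of compound 2 with a 4-methylpiperazin-1-yl

This account rests on a few compounds, and the source may have more. Where it says the series, first, only, none or still open, it means among the compounds named here.

Compound 2 `Nc1ccccc1NC(=O)c1ccc(Cn2cnc3c(Nc4ccccc4)nc(Cl)nc32)cc1` is one of three compounds for which a number is known in a functional assay on NCI-H460 cells (Homo sapiens) for antiproliferative activity, read by CCK-8 assay, with a stated time of 72 h, tested at 8 uM; on this read-out lower numbers stand for a weaker effect and higher numbers for a stronger effect at the one concentration tested. In this assay compound 2 gives 77.8%, the highest of the three. Compound 1 `COC(CCn1cnc2c(NCc3ccc(C(=O)Nc4ccccc4N)cc3)nc(Cl)nc21)OC` gives 51.2% in this assay, and compound 3 `Nc1ccccc1NC(=O)/C=C/c1ccc(COCNc2nc(Nc3cccc(Cl)c3)c3ncn(C4CCCC4)c3n2)cc1` gives 46.1%; both stand beyond the scatter below compound 2.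

Compound 4 `CN1CCN(c2nc(Cl)nc3c2ncn3Cc2ccc(C(=O)Nc3ccccc3N)cc2)CC1` differs from compound 2 in one place: 4-methylpiperazin-1-yl in place of anilino on an aromatic carbon. Among the measured compounds shown here, no pair of measured compounds shows this change on its own, so nothing about its effect is known from the numbers given. For the measured compounds named here, the only measured change away from the pattern of compound 2, the one seen in compound 1 with its value of 51.2%, lies at another place on the core and runs downward.

Compound 4 is therefore expected to lose activity, with an estimated step of a number 22.8 percentage points lower from compound 2 to compound 4 (beyond the scatter) beyond the scatter. The estimate for compound 4 in this assay is 55%, with a range from 30% to 78%.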

Compound 4, a percentage reported as inhibition, at one concentration (the size of the read-out at that concentration, not a potency): 55.1%
Compound 4: middle estimate off by 0.1 percentage points, on the low side; the range from low to high includes it.
By their numbers in this assay, from the lowest: compounds 3, 1 and 4 (each within the scatter of the next); then compound 2.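

In this assay, the one-place change from anilino to 4-methylpiperazin-1-yl gives a number 22.7 percentage points lower from compound 2 to compound 4 (beyond the scatter), the first direct sign that this position responds to the group it carries. The fall comes with no change in heavy-atom count, while an aromatic ring of carbon only gives way to a non-aromatic ring with 2 hetero atoms, and the hydrogen-bond donor of anilino is lost. The data do not show which of these differences matters for the step.

A single change cannot separate the ring from the linking nitrogen and its hydrogen. Going by these compounds, a cyclohexylamino group, with a non-aromatic ring on an amine nitrogen that keeps its hydrogen, and N-methylanilino, with the aromatic ring but no such hydrogen, would each vary one of these features, and how either would read here remains open.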